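The source may report more compounds than this note shows. Statements on the series, on what has been measured and on what is new or still open speak of the compounds shown alone.

- Compound 1 `O=C(O)c1nc(C2CCCCC2)n(-c2cccc(Cl)c2F)c1-c1ccc(F)c(Cl)c1` gives > 30000 nM (a limit)
- Compound 2 `Cc1nnc(-c2nc(C3CCCCC3)n(-c3cccc(Cl)c3F)c2-c2ccc(F)c(Cl)c2)o1` gives > 30000 nM (a limit)
- Compound 3 `NC(=O)c1nc(C2CCCCC2)n(-c2cccc(Cl)c2F)c1-c1ccc(F)c(Cl)c1` gives 29000 nM

Within the data shown here, in a functional assay on SAOS-2 cells (Homo sapiens) for antiproliferative activity, read by fluorescence, with a stated time of 72 h (on this read-out lower numbers stand for stronger inhibition and higher numbers for weaker inhibition), compound 3 gives 29000 nM, the only true number among the three. Compound 1 and compound 2 yield only a limit, namely (the limit of > 30000 nM in this assay, at which 2 of the 3 values shown sit).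

Compound 4 `Nc1nnc(-c2nc(C3CCCCC3)n(-c3cccc(Cl)c3F)c2-c2ccc(F)c(Cl)c2)o1` carries 5-amino-1,3,4-oxadiazol-2-yl in place of carbamoyl on an aromatic carbon. Compound 2, bearing 5-methyl-1,3,4-oxadiazol-2-yl, likewise stops at its limit of > 30000 nM. The bearing steps are small or unreadable: an at least 1.0-fold lower number from compound 2 to compound 3 (0.01 log units; that floor lies within the scatter) and an at least 1.0-fold lower number from compound 1 to compound 3 (0.01 log units; that floor lies within the scatter) are floors within the scatter, and a step that the two limits leave unreadable from compound 1 to compound 2 cannot be sized. No step beyond the scatter is therefore expected in this assay, and the expected change is a 1.0-fold lower number from compound 3 to compound 4 (0.02 log units; within the scatter). For compound 4 the estimate is 28000 nM, within an expected range of 10000 nM to 45000 nM.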

Compound 4, half-maximal inhibitory concentration: > 30000 nM
Compound 4 was reported as a limit (the forecaster's own chance of this, stated with the estimate: 60%); middle value at least 1.0-fold (0.02 log units) from the limit.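

Placing 5-amino-1,3,4-oxadiazol-2-yl in place of carbamoyl on this aromatic carbon gives, in this assay, an at least 1.0-fold higher number from compound 3 to compound 4 (0.01 log units; that floor lies within the scatter), so this ring with its amino group brings no readable gain over carbamoyl. The steps to compound 4 from compound 1 and compound 2 cannot be read, as both ends of each are limits. Only one true number now remains at this position: the limit of > 30000 nM in this assay, at which 3 of the 4 values shown sit.

The compounds shown leave open whether any group here gives a clearly lower number. A hydroxymethyl, an aminomethyl or a methyl ester on this carbon remains untested in what is shown.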